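Swapping the aryl sulfonamide toward a dichlorophenyl

The source may report more compounds than this note shows. Statements on the series, on what has been measured and on what is new or still open speak of the compounds shown alone.

Compound 3 `Cc1ccccc1S(=O)(=O)Nc1ccc(-c2nc3ccccc3o2)cc1` stands no higher than the threshold of an assay on isolated protein for inhibition of malate dehydrogenase, mitochondrial (Sus scrofa), with stated times of 45 min and 30 min; a higher number here means a weaker inhibitor, a lower number a stronger inhibitor: compound 3 gives > 63000 nM, a limit of the assay rather than a number. Compound 1 `O=S(=O)(Nc1ccc(-c2nc3ccccc3o2)cc1)c1cccc(Cl)c1` gives > 63000 nM, likewise a limit. Compound 2 `O=S(=O)(Nc1ccc(-c2nc3ccccc3o2)cc1)c1ccc(O)cc1` gives > 63000 nM, again only a limit. The steps a step that the two limits leave unreadable from compound 1 to compound 2, a step that the two limits leave unreadable from compound 1 to compound 3 and a step that the two limits leave unreadable from compound 2 to compound 3 therefore cannot be sized, because of the limit of > 63000 nM in this assay, at which 3 of the 3 values shown sit. Compound 4 `O=S(=O)(Nc1ccc(-c2nc3ccccc3o2)cc1)c1ccc(Cl)c(Cl)c1` carries 3,4-dichlorophenyl in place of 2-methylphenyl on a sulfonyl sulfur. Since every shown aryl substituent leaves the read-out at the same limit, no step beyond the scatter in this assay can be foreseen in either direction. For compound 4 the expected value is 80000 nM, within 20000 nM to 300000 nM. The step that the limit leaves unreadable from compound 3 to compound 4 is thus estimated as essentially none.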

Compound 4, half-maximal inhibitory concentration: > 63000 nM
Compound 4: no number, only a limit; the forecaster's own chance of this, stated with the estimate: 80%; the middle value is on the limit's open side.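

Compound 4 gives only a limit, so the steps to it from compound 1, compound 2 and compound 3 cannot be read: the limit of > 63000 nM in this assay, at which 4 of the 4 values shown sit. The compounds shown leave open whether any aryl group on the sulfonyl sulfur gives a measurable value in this assay.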